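Replacing Fluoro with Pyridin-3-yl in a Permeability Series

A few compounds are considered here, and "the series" means these few. Any claim that something is new, unique, unknown or untested is made for them only; others in the source may bear on it.

Compound 1 `CNC(=O)c1cc(Oc2ccc3nc(Nc4cccc(C(C)C)c4)ncc3c2)ccn1`: in an ADME assay on Caco-2 cells (Homo sapiens) for permeability, in the apical to basolateral direction (a lower number here means that the compound crosses the layer more slowly, a higher number that the compound crosses the layer faster), compound 1 gives < 1 10^-6 cm/s, which is a limit of the assay.
Compound 2 `CNC(=O)c1cc(Oc2ccc3nc(Nc4ccc(F)cc4)ncc3c2)ccn1`: in this assay compound 2 gives < 1 10^-6 cm/s, also a limit.

Compound 2 stands at the limit of < 1 10^-6 cm/s in this assay, at which 2 of the 2 values shown sit. Among the compounds with values here, the single measured step, a step that the two limits leave unreadable from compound 1 to compound 2, cannot be sized because both of its ends are limits. Compound 3 `CNC(=O)c1cc(Oc2ccc3nc(Nc4ccc(-c5cccnc5)cc4)ncc3c2)ccn1` differs from compound 2 by pyridin-3-yl in place of fluoro on an aromatic carbon. Within the data shown here, no measured step bears on this change, so the data give no direction beyond the scatter to expect in this assay. Compound 3 is therefore expected to sit at about 0.7 10^-6 cm/s, with a range from 0.2 10^-6 cm/s to 3 10^-6 cm/s. This estimate means an expected step that the limit leaves unreadable from compound 2 to compound 3.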

Compound 3, apparent permeability: < 1 10^-6 cm/s
Compound 3 gave a limit, no number; the forecaster's own chance of this, stated with the estimate: 65%; the middle value is on the limit's open side.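

Within the data shown here, compound 2 and compound 3 each give only a limit, and no step between them can be read. How fast compounds 1, 2 and 3 actually cross the layer stays open, with every value at one limit: the limit of < 1 10^-6 cm/s in this assay, at which 3 of the 3 values shown sit.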